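Notes on a cytotoxicity series: hydroxy to dimethylamino

The source may hold more compounds than are shown below. What is called first, only, known or untested is meant among the compounds shown, and "the series" means these compounds.

Three compounds of this series carry numbers in a functional assay on L132 cells (Homo sapiens) for cytotoxicity, read by MTT assay, with a stated time of 72 h; on this read-out lower numbers stand for an effect already at smaller amounts and higher numbers for an effect only at larger amounts of compound. Compound 1 `O=C1/C(=C\c2ccc(O)cc2)c2ccccc2N1c1c(Cl)cccc1Cl` gives 30 ug/mL in this assay. Compound 2 `Cc1ccc2nc(Cl)c(/C=C3\C(=O)N(c4c(Cl)cccc4Cl)c4ccccc43)cc2c1C` gives 98 ug/mL in this assay, and compound 3 `O=C1/C(=C\c2cccc(Oc3ccccc3)c2)c2ccccc2N1c1c(Cl)cccc1Cl` gives 24 ug/mL in this assay. Among these three numbers compound 1 stands second highest; the nearest is compound 3, whose number lies within the scatter of that of compound 1, so no order between the two can be read. The furthest is compound 2, whose number lies beyond the scatter, higher than that of compound 1. Among the compounds with values here, no two measured compounds differ in one place only, so no single step in this assay has been measured directly.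

Compound 4 `CN(C)c1ccc(/C=C2\C(=O)N(c3c(Cl)cccc3Cl)c3ccccc32)cc1` is not yet measured. It differs from compound 1 in one place: dimethylamino in place of hydroxy on an aromatic carbon, in words dimethylamino in place of hydroxy on an aromatic carbon. Within the data shown here, no measured step speaks to this change, and nothing in the three numbers points in either direction. The step is therefore expected to be no change at the digits printed from compound 1 to compound 4 (within the scatter), that is, none beyond the scatter. On that basis compound 4 is estimated at 30 ug/mL in this assay, with a range from 10 ug/mL to 90 ug/mL.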

Compound 4, concentration for half-maximal effect: > 100 ug/mL
Compound 4: no number, only a limit; the forecaster's own chance of this, stated with the estimate: 5%; middle value at least 3.3-fold (0.52 log units) from the limit.
By their numbers in this assay, from the lowest: compounds 3 and 1 (each within the scatter of the next); then compound 2. At a limit, above all of these: compound 4.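

The series now has its first step that changes one place only, and it falls on the aromatic carbon para to a large group: in this assay, dimethylamino in place of hydroxy gives an at least 3.3-fold higher number from compound 1 to compound 4 (0.52 log units; beyond the scatter). Compound 4 carries a limit of the assay and not a number, and it stands alone there among the compounds shown: the limit of > 100 ug/mL in this assay, at which 1 of the 4 values shown sits. The earlier compounds shown here could not show that this place responds to a change of group, since no two of them differed in one place only; the step from 4-hydroxyphenyl to 4-(dimethylamino)phenyl now shows that, on the core of compound 1, the exchange moves the read-out beyond the scatter, with the full size of the step left unknown.

The compounds shown do not separate the departure of the hydroxy from the arrival of the dimethylamino. A methoxy, a primary amine or a carboxylic acid at the same place would tell whether the step follows the hydroxy alone or the group that enters.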